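Trading a Large Ring Group for Cyclopropyl

The source may report more compounds than this note shows. Statements on the series, on what has been measured and on what is new or still open speak of the compounds shown alone.

In a physicochemical assay for solubility, measured as kinetic solubility (a higher number here means a more soluble compound, a lower number a less soluble compound), compound 1 (`CCC/N=C1\S/C(=C\c2ccc(O)c(Cl)c2)C(=O)N1C1CCN(C)C(=O)C1`) gives > 250000 nM and this is a limit of the assay, not a number. Compound 2 (`CCC/N=C1\S/C(=C\c2ccc(O)c(Br)c2)C(=O)N1c1ccccc1C`) gives 79000 nM in this assay as an exact reading.

Compound 3 (`CCC/N=C1\S/C(=C\c2ccc(O)c(Cl)c2)C(=O)N1C1CC1`) has not yet been measured. It carries cyclopropyl in place of 1-methyl-2-oxopiperidin-4-yl on an amide-type nitrogen in a ring. Within the data shown here, no measured step isolates this change, so any forecast here is loose. Among the measured compounds shown here, the only exact reading to lean on is compound 2 at 79000 nM and it suggests that readings of this size do occur. The expected step of an at least 2.5-fold lower number from compound 1 to compound 3 (0.39 log units; beyond the scatter) is a drop beyond the scatter. The estimated value for compound 3 is 100000 nM with an expected range from 35000 nM to 250000 nM in this assay.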

Compound 3, solubility: 79000 nM
Compound 3: the middle estimate sits 1.3-fold (0.10 log units) above what was measured, within the range that was stated.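

Among these compounds, replacing 1-methyl-2-oxopiperidin-4-yl with cyclopropyl on the amide-type nitrogen gives the first readable step at this position in this assay, and it shows that this group can shift the reading beyond the scatter: an at least 3.1-fold lower number from compound 1 to compound 3 (0.50 log units; beyond the scatter). Compound 1 gives > 250000 nM, which is a limit of the assay and not a number. The full size of the step therefore cannot be read, and only its minimum is known: the limit of > 250000 nM in this assay, at which 1 of the 3 values shown sits.

The change swaps a larger six-membered ring containing nitrogen and oxygen for a small all-carbon ring, so this single step cannot show whether the lower number follows the size of the group or the loss of those hetero atoms. A cyclohexyl group or a piperidin-4-yl group without the carbonyl at this position would help separate the two.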